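Swapping the bicyclic amine substituent for an oxolane ring

The source may hold more compounds than are shown below. What is called first, only, known or untested is meant among the compounds shown, and "the series" means these compounds.

Compound 1, `O=C(O)c1cnn(-c2nc(NC34CCC(CC3)C4)c3ncn([C@@H]4O[C@H](CO)[C@@H](O)[C@H]4O)c3n2)c1`: 1 nM
Compound 2, `CCOC(=O)c1cnn(-c2nc(NC34CCC(CC3)C4)c3ncn([C@@H]4O[C@H](CO)[C@@H](O)[C@H]4O)c3n2)c1`: 3 nM
Compound 3, `CCNC(=O)c1cnn(-c2nc(NC3CCCC3)c3ncn([C@@H]4O[C@H](CO)[C@@H](O)[C@H]4O)c3n2)c1`: 1 nM

All three were measured in an assay on cell membranes (Cricetinae) for displacement of a labelled ligand from adenosine receptor A1 (Homo sapiens); a higher number here means a weaker inhibitor, a lower number a stronger inhibitor. Compound 1 gives 1 nM, and compound 3 gives 1 nM; the two stand level at the digits shown and together sit at the lowest numbers of the set. Compound 2 is the odd one out: the change a 3.0-fold higher number from compound 1 to compound 2 (0.48 log units; beyond the scatter), ethyl in place of hydrogen on an oxygen next to a carbonyl group, is a modest but real rise.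

Compound 4, `O=C(O)c1cnn(-c2nc(N[C@H]3CCCO3)c3ncn([C@@H]4O[C@H](CO)[C@@H](O)[C@H]4O)c3n2)c1`, alters a different part of compound 1: a group of 5 heavy atoms (4 carbon, 1 oxygen; one five-membered non-aromatic ring with 1 hetero atom) in place of a group of 7 heavy atoms (7 carbon; 2 five-membered non-aromatic rings of carbon only), on a nitrogen on an aromatic ring. Among the measured compounds shown here, no measured step covers this exact change. For the measured compounds named here, the one measured step concerns the ester end of the molecule, not the amine substituent, and compound 3 differs from compound 1 in two places at once; its value shows only that a smaller carbon ring on that nitrogen, combined with another amide, still leaves compound 3 at 1 nM. Replacing an all-carbon bicycle with a smaller oxygen-containing ring is a larger departure than anything measured here, so a modest weakening is expected, a 5.0-fold higher number from compound 1 to compound 4 (0.70 log units; beyond the scatter). Compound 4 is therefore estimated at 5 nM, with a range from 1.5 nM to 20 nM.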

Compound 4, inhibition constant: 24 nM
The estimate for compound 4 lay 4.8-fold (0.68 log units) below the measured number; measured number above the stated range.
By their numbers in this assay, from the lowest: compounds 1 and 3 (each within the scatter of the next); then compound 2; then compound 4.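

At this position, on a nitrogen on an aromatic ring, the choice of group counts for much: in this assay, oxolan-2-yl in place of the bicyclic group gives a 24-fold higher number from compound 1 to compound 4 (1.38 log units; beyond the scatter), a large step, whereas the change at the other end of the molecule gives only a modest one, a 3.0-fold higher number from compound 1 to compound 2 (0.48 log units; beyond the scatter). This single swap changes several things at once, since the entering group has fewer heavy atoms, one hydrogen-bond acceptor and a defined stereocentre, so the step cannot be pinned on any one of them. Nothing available here explains the size of this step.

The compounds shown leave open whether the smaller ring or its oxygen matters more. A cyclopentyl group paired with the carboxylic acid, or a cyclohexyl group on the same nitrogen, would help separate the two, and the oxolan-2-yl group with its stereocentre reversed would test the role of that centre.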